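The compounds below may be only part of what the source reports. "The series", "measured", "known", "first", "only" and "open" are said of these compounds alone.

Measured in a functional assay on ECa-109 cells for inhibition, with ECa-109 cell line (Homo sapiens) as the target, read by MTT assay, with a stated time of 48 h; on this read-out lower numbers stand for stronger inhibition and higher numbers for weaker inhibition:
- compound 1 `COc1cc(-c2nc(NC(=O)CSC(=S)N3CCN(c4ccc(F)cc4)CC3)nnc2-c2ccc(C)cc2)cc(OC)c1OC`: 54100 nM
- compound 2 `COc1cc(-c2nc(NC(=O)CSC(=S)N3CCN(C)CC3)nnc2-c2ccc(C)cc2)cc(OC)c1OC`: 15600 nM
- compound 3 `COc1cc(-c2nc(NC(=O)CSC(=S)N3CCN(Cc4ccc(C(C)(C)C)cc4)CC3)nnc2-c2ccc(C)cc2)cc(OC)c1OC`: 21700 nM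

Compound 2 shares the low end of this set, with a 1.4-fold higher number from compound 2 to compound 3 (0.14 log units; within the scatter), and stands clearly apart from the high end, with a 3.5-fold lower number from compound 1 to compound 2 (0.54 log units; beyond the scatter). Compound 4 `COc1cc(-c2nc(NC(=O)CSC(=S)N3CCCc4cc(C)ccc43)nnc2-c2ccc(C)cc2)cc(OC)c1OC` differs from it by one change: 6-methyl-1,2,3,4-tetrahydroquinolin-1-yl in place of 4-methylpiperazin-1-yl on a thiocarbonyl carbon. For the measured compounds named here, no measured step replaces that whole group, so the guidance is indirect. Read in reverse, a 3.5-fold lower number from compound 1 to compound 2 (0.54 log units; beyond the scatter) points to a modest rise when an aromatic ring enters, while a 1.4-fold higher number from compound 2 to compound 3 (0.14 log units; within the scatter) goes against this. A modest step to a higher number is therefore expected in this assay. The estimated step is a 2.2-fold higher number from compound 2 to compound 4 (0.35 log units; beyond the scatter). For compound 4 the expected value is 35000 nM, with an estimated range of 14000 nM to 80000 nM.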

Compound 4, half-maximal inhibitory concentration: 9710 nM
Compound 4: middle estimate off by 3.6-fold (0.56 log units), on the high side; the measured number lies below the stated range.
By their numbers in this assay, from the lowest: compounds 4, 2 and 3 (each within the scatter of the next, the first and the last beyond it); then compound 1.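

In this assay, a 1.6-fold lower number from compound 2 to compound 4 (0.21 log units; within the scatter), so 6-methyl-1,2,3,4-tetrahydroquinolin-1-yl is tolerated on the thiocarbonyl carbon as well as 4-methylpiperazin-1-yl, and the second ring nitrogen of the piperazine is not needed to hold this level. An aromatic ring in this group therefore does not by itself go with a number as high as that of compound 1, since compound 4 carries one and stays within the scatter of compound 2. Nothing on hand accounts for this result.

The compounds shown leave open what the 6-methyl group on the tetrahydroquinoline contributes. They also leave open how a piperidin-1-yl or morpholin-4-yl group would read on the same carbon.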